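Working notes: from compound 2 to compound 4

A few compounds are considered here, and "the series" means these few. Any claim that something is new, unique, unknown or untested is made for them only; others in the source may bear on it.

In an ADME assay on microsomes from liver (Homo sapiens) for metabolic stability, read by LC-MS, using NADPH, with a stated time of 10 min, tested at 0.5 uM (a lower number here means that less of the compound is left, a higher number that more of the compound is left), compound 2 `Cc1cc(-c2cc(Cl)c(OC[C@@](C)(N)CC(C)C)cn2)ccn1` gives 86% and so lies within the usual scatter of compound 1 `COC(=O)Nc1cc(-c2cnc(OC[C@@](C)(N)CC(C)C)c(Cl)c2)ccn1` at 90% and of compound 3 `Cc1cc(-c2cc(C)c(OC[C@@](C)(N)CC(C)C)cn2)ccn1` at 79% in the same read-out. All three sit in a narrow band with no separation between them.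

The change to compound 4 `CC(C)C[C@](C)(N)COc1cnc(-c2ccnc(Cl)c2)cc1Cl` is chloro in place of methyl on an aromatic carbon and reads in words as chloro in place of methyl on an aromatic carbon, next to the ring nitrogen, so that 2-methylpyridin-4-yl becomes 2-chloropyridin-4-yl.

Within the data shown here, no measured pair changes that group. The nearest evidence is a number 7 percentage points lower from compound 2 to compound 3 (within the scatter) for methyl in place of chloro on an aromatic carbon. That swap runs the opposite way at another aromatic carbon, so it bears on the new step only indirectly, and it stays within the scatter.

The step expected in this assay is therefore none beyond the scatter, estimated as a number 1 percentage points higher from compound 2 to compound 4 (within the scatter) and with no firm direction. The estimate for compound 4 is 87% with an expected range from 75% to 97% for repeated measurements.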

Compound 4, percent of the compound remaining: 86%
Beside the measured number, compound 4's estimate is 1 percentage points above it, within the range that was stated.
By their numbers in this assay, from the lowest: compounds 3, 2, 4 and 1 (each within the scatter of the next, the first and the last beyond it).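

In this assay, among these compounds, the first measured change of this group, 2-methylpyridin-4-yl to 2-chloropyridin-4-yl, gives no change at the digits printed from compound 2 to compound 4 (within the scatter). At this aromatic carbon, next to the ring nitrogen, the read-out therefore does not separate chloro from methyl, a point that earlier pairs could address only indirectly. The other measured exchange of these two groups, at a different aromatic carbon, gives a number 7 percentage points lower from compound 2 to compound 3 (within the scatter), so neither of the two pairs shows a step beyond the scatter, though two pairs establish no general rule for the series. No available data explain this outcome or link it to any property of either group.

Going by these compounds, it remains open whether a group of a different kind at this place, such as an amine, a methoxy group or a carboxylic acid, would also leave the percentage remaining within the scatter of compound 2. Also open, on these data alone, is whether chloro in place of methyl at this same carbon would read alike on the core of compound 3.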